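The source may report more compounds than this note shows. Statements on the series, on what has been measured and on what is new or still open speak of the compounds shown alone.

Measured compounds:
- compound 1 `Cc1c(O)c(=O)ccn1CC(=O)N/N=C1\C(=O)N(CC(=O)Nc2ccc(Br)cc2)c2ccccc21` — 29300 nM
- compound 2 `Cc1ccc(NC(=O)CN2C(=O)/C(=N\NC(=O)Cn3ccc(=O)c(O)c3C)c3ccccc32)cc1` — 47500 nM
- compound 3 `CC(=O)Nc1ccc(NC(=O)CN2C(=O)/C(=N\NC(=O)Cn3ccc(=O)c(O)c3C)c3ccccc32)cc1` — > 100000 nM

In a functional assay on A549 cells (Homo sapiens) for cytotoxicity, read by MTT assay, with a stated time of 48 h (a lower number here means that less compound is needed, a higher number that more compound is needed for the effect), compound 1 gives 29300 nM. Compound 2 gives 47500 nM in this assay. Compound 3 reaches only a limit of the assay, > 100000 nM, so no number is known for it (the limit of > 100000 nM in this assay, at which 1 of the 3 values shown sits); compound 3 stands at the high end of what has been measured here. Compound 4 `Cc1c(O)c(=O)ccn1CC(=O)N/N=C1\C(=O)N(CC(=O)Nc2ccccc2Cl)c2ccccc21` differs from compound 3 in that (2-chlorophenyl in place of 4-acetamidophenyl on an amide-type nitrogen). Within the data shown here, the steps that bear on this are the reverse of those leading to compound 3: an at least 3.4-fold higher number from compound 1 to compound 3 (0.53 log units; beyond the scatter) and an at least 2.1-fold higher number from compound 2 to compound 3 (0.32 log units; beyond the scatter). A return to a halogen-bearing phenyl is therefore expected to bring the number down in this assay by an at least 2.8-fold lower number from compound 3 to compound 4 (0.45 log units; beyond the scatter). Compound 4 is estimated at 35000 nM, between 15000 nM and 100000 nM.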

Compound 4, half-maximal effective concentration: > 100000 nM
Compound 4: no number, only a limit; the forecaster's own chance of this, stated with the estimate: 25%; middle value at least 2.8-fold (0.45 log units) from the limit.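

In this assay compound 4 also reaches only a limit of the assay, not a number: the limit of > 100000 nM in this assay, at which 2 of the 4 values shown sit.

A halogen on the phenyl therefore does not by itself keep a readable value at this amide-type nitrogen, as the 2-chlorophenyl change gives an at least 3.4-fold higher number from compound 1 to compound 4 (0.53 log units; beyond the scatter) and an at least 2.1-fold higher number from compound 2 to compound 4 (0.32 log units; beyond the scatter). The step between compound 3 and compound 4 cannot be read, as both are limits.

Going by these compounds, whether 4-chlorophenyl would read like the 4-bromophenyl of compound 1 or like the 2-chlorophenyl of compound 4 stays open. So does the reading of a phenyl carrying an amine or a carboxylic acid.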